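The compounds below may be only part of what the source reports. "The series", "measured", "known", "first", "only" and "open" are said of these compounds alone.

Measured so far in this series:
- compound 1 `CCCNc1nnc(SCC(=O)N(Cc2cccc([N+](=O)[O-])c2)c2ccc(F)cc2)s1`: 78.3%
- compound 2 `CCNc1nnc(SCC(=O)N(Cc2cccc([N+](=O)[O-])c2)c2ccc(F)cc2)s1`: 74.1%

Both numbers come from an assay on isolated protein for inhibition of Amine oxidase [flavin-containing] A (Homo sapiens), read by fluorescence and Amplex Red, with a stated time of 30 min, tested at 10 uM; a lower number here means a weaker effect, a higher number a stronger effect of the compound at the concentration tested. Among the compounds with values here, compound 1 stands highest of the two, but its only neighbour is compound 2, and the step of a number 4.2 percentage points lower from compound 1 to compound 2 (within the scatter) is within the scatter, so the two values cannot be ranked against each other.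

The next compound to be measured is compound 3 `CC(C)Nc1nnc(SCC(=O)N(Cc2cccc([N+](=O)[O-])c2)c2ccc(F)cc2)s1`. Against compound 1 the change is isopropyl in place of propyl on a nitrogen on an aromatic ring; the same atoms are present, joined differently.

Within the data shown here, only one measured step exists, the step from compound 1 to compound 2, and it shortens the chain on the ring nitrogen rather than rearranging it; it was a number 4.2 percentage points lower from compound 1 to compound 2 (within the scatter) and did not leave the scatter. It bears on the present change only loosely, showing that the chain on that nitrogen has so far been tolerant of alteration. No step beyond the scatter is therefore expected in this assay for compound 3; the expected step is a number 2.3 percentage points lower from compound 1 to compound 3 (within the scatter). Compound 3 is estimated at 76%, with a range from 63% to 87%.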

Compound 3, a percentage reported as inhibition, at one concentration (the size of the read-out at that concentration, not a potency): 86.1%
Compound 3: the middle estimate sits 10.1 percentage points below what was measured; measured number inside the range.
By their numbers in this assay, from the lowest: compounds 2, 1 and 3 (each within the scatter of the next, the first and the last beyond it).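

Moving from a straight to a branched chain on the nitrogen on the aromatic ring is tolerated in this assay: isopropyl in place of propyl gives a number 7.8 percentage points higher from compound 1 to compound 3 (within the scatter) and leaves the two isomeric chains unseparated. Methyl in place of hydrogen on the chain carbon bound to that nitrogen gives a number 12 percentage points higher from compound 2 to compound 3 (beyond the scatter) and is the first step in the series to leave the scatter, although only modestly, so this position can respond to a small change in the chain. Compound 1 stays within the scatter of both compound 2 and compound 3, so only the two ends of this short set are separated, and no information on the cause of either step is available.

With compound 1 unresolved from both neighbours, the compounds shown do not separate the contribution of branching from that of chain length. Also open, as far as these compounds go, is how tert-butyl, cyclopropyl, a longer chain such as butyl or an unsubstituted amino group at this position would read in this assay and whether any such change would hold up as a potency rather than as a reading at one concentration.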